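The compounds below may be only part of what the source reports. "The series", "measured", "known", "first", "only" and "open" are said of these compounds alone.

Measured in a functional assay on PC-3 cells (Homo sapiens) for antiproliferative activity, read by MTT assay, with a stated time of 24 h; on this read-out higher numbers stand for weaker inhibition and lower numbers for stronger inhibition:
Compound 1 `CCn1c(C(=O)NCC(=O)OC)ccc1C(CC)(CC)c1ccc(OCS(=O)(=O)c2ccccc2)c(C)c1`: > 50000 nM, a limit
Compound 2 `CCn1c(C(=O)NCCCO)ccc1C(CC)(CC)c1ccc(OCS(=O)(=O)c2ccccc2)c(C)c1`: 11300 nM
Compound 3 `CCn1c(C(=O)NC2(C(=O)O)CC2)ccc1C(CC)(CC)c1ccc(OCS(=O)(=O)c2ccccc2)c(C)c1`: 26300 nM

Compound 1 stands at the limit of > 50000 nM in this assay, at which 1 of the 3 values shown sits. Compound 3 holds the higher of the two actual numbers. The step that shows this is a 2.3-fold higher number from compound 2 to compound 3 (0.37 log units; beyond the scatter).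

Compound 4 `CCn1c(C(=O)N[C@@H](C(=O)O)C(C)C)ccc1C(CC)(CC)c1ccc(OCS(=O)(=O)c2ccccc2)c(C)c1` differs from compound 3 as follows: 1-carboxy-2-methylpropyl in place of 1-carboxycyclopropyl on an amide-type nitrogen. The ring goes, the carboxy group stays, and a defined stereocentre enters.

Two other measured steps change the group on the same amide-type nitrogen: an at least 4.4-fold lower number from compound 1 to compound 2 (0.64 log units; beyond the scatter), and an at least 1.9-fold lower number from compound 1 to compound 3 (0.27 log units; that floor lies within the scatter), whose floor lies within the scatter. For the measured compounds named here, none of the measured steps swaps one carboxy-bearing group for another, so their bearing is indirect. The exactly sized guide is compound 3 with a 2.3-fold higher number from compound 2 to compound 3 (0.37 log units; beyond the scatter), a modest step between groups less alike than the present pair. A smaller change is therefore expected in this assay, with no firm direction. The expected step is a 1.2-fold lower number from compound 3 to compound 4 (0.08 log units; within the scatter), not beyond the scatter. For compound 4 the estimated value is 22000 nM, with an expected range of 9000 nM to 50000 nM.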

Compound 4, half-maximal inhibitory concentration: 3070 nM
Beside the measured number, compound 4's estimate is 7.2-fold (0.86 log units) above it, and the stated range ends above it.
By their numbers in this assay, from the lowest: compound 4; then compound 2; then compound 3. At a limit, above all of these: compound 1.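

In this assay, the carboxy group is kept while the rest of the group on the amide-type nitrogen changes, and 1-carboxy-2-methylpropyl in place of 1-carboxycyclopropyl gives an 8.6-fold lower number from compound 3 to compound 4 (0.93 log units; beyond the scatter); the read-out at this position therefore does not follow the carboxy group alone. With a 3.7-fold lower number from compound 2 to compound 4 (0.57 log units; beyond the scatter), the 3-hydroxypropyl compound now lies between two carboxy-bearing compounds, compound 3 on the weaker side and compound 4 on the stronger. Compound 1 is a limit, so an at least 16-fold lower number from compound 1 to compound 4 (1.21 log units; beyond the scatter) gives only a floor for that step.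

The loss of the ring and the arrival of the defined stereocentre come together in this one change, and the compounds shown do not separate them. A 1-carboxyethyl group, or the opposite configuration of the 1-carboxy-2-methylpropyl group, would bear on that question.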